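Ring stereocentres: from compound 2 to compound 3

This account rests on a few compounds, and the source may have more. Where it says the series, first, only, none or still open, it means among the compounds named here.

Measured in an ADME assay (liver) for metabolic stability, with Liver microsome (Rattus norvegicus) as the target, using microsomes, with a stated time of 30 min; on this read-out higher numbers stand for a more stable compound and lower numbers for a less stable compound:
- compound 1 `COC(=O)N[C@H](C(=O)N1CCC[C@H]1C(=O)Nc1ccc([C@H]2CC[C@H](c3ccc(NC(=O)[C@@H]4CCCN4C(=O)[C@@H](NC(=O)OC)C(C)C)cc3)N2c2ccc(C(F)(F)F)cc2)cc1)C(C)C`: 58%
- compound 2 `COC(=O)N[C@H](C(=O)N1CCC[C@H]1C(=O)Nc1ccc([C@H]2CC[C@H](c3ccc(NC(=O)[C@@H]4CCCN4C(=O)[C@@H](NC(=O)OC)C(C)(C)C)cc3)N2c2ccc(F)cc2)cc1)C(C)(C)C`: 69%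

Compound 2 stands higher of the two, at 69%, a gap to compound 1 that lies beyond the scatter. Compound 3 `COC(=O)N[C@H](C(=O)N1CCC[C@H]1C(=O)Nc1ccc([C@@H]2CC[C@@H](c3ccc(NC(=O)[C@@H]4CCCN4C(=O)[C@@H](NC(=O)OC)C(C)(C)C)cc3)N2c2ccc(F)cc2)cc1)C(C)(C)C` keeps the atoms and bonds of compound 2 and differs only in configuration as drawn: the two compounds have the same atoms and bonds and differ only in configuration as drawn: 2 of 6 stereo elements differ; a stereocentre at a saturated ring carbon is drawn R in compound 2 and S in compound 3; a stereocentre at a saturated ring carbon is drawn R in compound 2 and S in compound 3. Going by the values given here, no measured pair shows what such a change does in this assay, so the expectation is loose. A small fall within the scatter is expected, the estimated step being a number 4 percentage points lower from compound 2 to compound 3 (within the scatter). For compound 3 the estimated value is 65%, with an expected range of 50% to 80%.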

Compound 3, percent of the compound remaining: 56%
Estimate against measurement, compound 3: 9 percentage points above; the measured number falls inside the stated range.
By their numbers in this assay, from the lowest: compounds 3 and 1 (each within the scatter of the next); then compound 2.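

In this assay, changing the two saturated ring carbons from R to S as drawn gives a number 13 percentage points lower from compound 2 to compound 3 (beyond the scatter). Going by these compounds alone, this is the first pair to isolate a single kind of change, showing that this read-out responds to configuration at these ring carbons. The step can be assigned to that change alone because of the following: the fact that compounds 2 and 3 differ only in the configuration as drawn

Whether one stereocentre or both account for the step remains open. Also open, going by these compounds, is whether the same change in configuration would give a similar step with a nitrile or a methoxy group in place of the fluorine.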